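The source may report more compounds than this note shows. Statements on the series, on what has been measured and on what is new or still open speak of the compounds shown alone.

Three close relatives of the same core have been tested in a functional assay on T-24 cells (Homo sapiens) for cytotoxicity, read by CCK-8 assay, with a stated time of 24 h; a lower number here means a stronger inhibitor, a higher number a weaker inhibitor. Compound 1, with the structure `C/C(=C\c1cc(-c2ccc(C#N)cc2)cs1)C(N)=O`, gives in this assay > 50000 nM, which is a limit of the assay rather than a number. Compound 2, with the structure `C/C(=C\c1cc(-c2ccc([N+](=O)[O-])cc2)cs1)C(N)=O`, gives in this assay > 50000 nM, again a limit. Compound 3, with the structure `C/C(=C\c1cc(-c2ccc(C(F)(F)F)cc2)cs1)C(N)=O`, gives in this assay > 50000 nM, also a limit. The changes among them are small swaps of a single group on the six-membered ring: a step that the two limits leave unreadable from compound 1 to compound 2, a step that the two limits leave unreadable from compound 1 to compound 3 and a step that the two limits leave unreadable from compound 2 to compound 3. Compound 3 therefore stands on no number of its own, only on a limit, and the same holds for the two compounds beside it, since (the limit of > 50000 nM in this assay, at which 3 of the 3 values shown sit).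

Compound 4, with the structure `COc1ccc(-c2csc(/C=C(\C)C(N)=O)c2)cc1`, differs from compound 3 in one place: methoxy in place of trifluoromethyl on an aromatic carbon. None of the three measured steps can say how large a swap at this position is. Each step runs from one limit to another. The change from compound 3 to compound 4 is expected to be of the same kind, so the step expected from compound 3 to compound 4 is a step that the limit leaves unreadable from compound 3 to compound 4, none beyond the scatter. Compound 4 is accordingly estimated at 60000 nM, within 20000 nM to 200000 nM, most likely again as a limit.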

Compound 4, half-maximal inhibitory concentration: > 50000 nM
Compound 4 gave a limit, no number (the forecaster's own chance of this, stated with the estimate: 80%); the middle value lies beyond the limit too.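

Among the compounds shown here, compound 4 also ends at a limit of the assay, so no step from compound 1, compound 2 or compound 3 to compound 4 can be read, and the size of these swaps stays unknown: the limit of > 50000 nM in this assay, at which 4 of the 4 values shown sit. The compounds shown leave open whether any group at this place on the six-membered ring would give a real number in this assay.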